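The source may hold more compounds than are shown below. What is called first, only, known or untested is meant among the compounds shown, and "the series" means these compounds.

Measured compounds:
compound 1, `COC(=O)c1c(Nc2ccc(F)cc2)sc(C(=O)c2ccc(OC)cc2)c1C`, 23.3%
compound 2, `COc1ccc(C(=O)c2sc(Nc3ccccc3)c(C(=O)O)c2C)cc1`, 59.5%
compound 3, `COc1ccc(Nc2sc(C(=O)c3ccc(OC)cc3)c(C)c2C(=O)O)cc1`, 41.2%

In a functional assay, with a stated time of 150 min, tested at 30 ug/mL (on this read-out higher numbers stand for a stronger effect at the one concentration tested and lower numbers for a weaker effect), compound 3 gives 41.2%, the second highest of the three numbers: compound 2 lies above it and compound 1 below it. Going by the values given here, the only single-place step among the measured compounds runs a number 18.3 percentage points lower from compound 2 to compound 3 (beyond the scatter), so adding the methoxy cost a modest amount of activity. Compound 4, `COc1ccc(C(=O)c2sc(Nc3ccc(F)cc3)c(C(=O)O)c2C)cc1`, has not yet been measured. It differs from compound 3 in one place: fluoro in place of methoxy on an aromatic carbon. Compound 1 carries the same fluoro on the same ring, but it also differs from compound 4 at the carboxylic acid, so its value does not count as a single-place step. Taking the methoxy away in the other direction, toward hydrogen, gained what the step from compound 2 to compound 3 lost; fluoro is expected to sit somewhere between those two outcomes. Compound 4 is therefore estimated to rise by a number 8.8 percentage points higher from compound 3 to compound 4 (within the scatter), to 50%, within a range of 30% to 70%.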

Compound 4, a percentage reported as activity, at one concentration (the size of the read-out at that concentration, not a potency): 10.5%
The estimate for compound 4 lay 39.5 percentage points above the measured number, and the stated range ends above it.
By their numbers in this assay, from the lowest: compound 4; then compound 1; then compound 3; then compound 2.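

In this assay, fluoro in place of methoxy gave a number 30.7 percentage points lower from compound 3 to compound 4 (beyond the scatter) and fluoro in place of hydrogen gave a number 49 percentage points lower from compound 2 to compound 4 (beyond the scatter) on the same aromatic carbon, so at this place the outcome does not simply follow from the two earlier groups, and compound 4 is the lowest of the four. With fluoro in place, the carboxylic acid compared with its methyl ester gave a number 12.8 percentage points lower from compound 1 to compound 4 (beyond the scatter) in this one pair, so the free acid does not by itself secure the higher number. Nothing available here accounts for these drops.

From the compounds shown here alone, whether the ester and the acid keep this order with hydrogen or methoxy on that ring remains open. So does what a chloro or an amino group at this place would give.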